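The source may report more compounds than this note shows. Statements on the series, on what has been measured and on what is new or still open speak of the compounds shown alone.

Compound 1 `Cc1nn(C2COC2)cc1Nc1nc(N)c2c(C#N)c(N3CCC[C@H]3C)n(C)c2n1` and compound 2 `C[C@@H]1CCCN1c1c(C#N)c2c(N)nc(Nc3cn(C)nc3C(F)(F)F)nc2n1C` share one core and differ in the group on the aromatic nitrogen of the five-membered ring. In an assay on isolated protein for inhibition of Leucine-rich repeat serine/threonine-protein kinase 2 (Homo sapiens), read by TR-FRET and LanthaScreen, with stated times of 50 min and 30 min, in the presence of a further agent that is not named here (a lower number here means a stronger inhibitor, a higher number a weaker inhibitor), compound 1 gives 38 nM; in this assay compound 2 gives 508 nM. Among the compounds with values here, of the two numbers so far, compound 1 holds the lower one, with a 13-fold higher number from compound 1 to compound 2 (1.13 log units; beyond the scatter). Compound 3 `Cc1nn(CC2(O)COC2)cc1Nc1nc(N)c2c(C#N)c(N3CCC[C@H]3C)n(C)c2n1` keeps the rest of compound 1 and changes only the group on that aromatic nitrogen: (3-hydroxyoxetan-3-yl)methyl in place of oxetan-3-yl on an aromatic nitrogen. Within the data shown here, the one measured step, from compound 1 to compound 2, alters this same position but together with the methyl-bearing ring carbon, so it bears on the new step only loosely and gives no clear direction. With no closer comparison, compound 3 is expected to stay near compound 1 in this assay, with a step of about a 1.3-fold higher number from compound 1 to compound 3 (0.12 log units; within the scatter), not clearly beyond the scatter. The estimate for compound 3 in this assay is 50 nM, within the range 18 nM to 140 nM.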

Compound 3, half-maximal inhibitory concentration: 57 nM
Compound 3: the middle estimate sits 1.1-fold (0.06 log units) below what was measured; measured number inside the range.
By their numbers in this assay, from the lowest: compounds 1 and 3 (each within the scatter of the next); then compound 2.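

In this assay, within the data shown here, the group on the aromatic nitrogen changes alone for the first time, and the step reads a 1.5-fold higher number from compound 1 to compound 3 (0.18 log units; within the scatter). The earlier step, a 13-fold higher number from compound 1 to compound 2 (1.13 log units; beyond the scatter), replaced the whole substituted five-membered ring, so it could not show what this position accepts when the rest of that ring stays fixed. Here (3-hydroxyoxetan-3-yl)methyl, with its hydrogen-bond donor and larger heavy-atom count, stands in place of oxetan-3-yl without a step beyond the scatter, and nothing on hand explains this outcome.

The compounds shown do not separate the contribution of the hydroxyl from that of the added carbon linking the oxetane to the aromatic nitrogen. Going by these compounds, it also remains open how this position responds to a group without the oxetane, such as an amine, a carboxylic acid or a longer chain.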